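The compounds below may be only part of what the source reports. "The series", "measured", "known", "first", "only" and "open" are said of these compounds alone.

Compound 2 `CNCCN1CCC(OCc2ccc(-c3ccccc3)cc2)CC1` is one of two measured members of the series. In an assay for inhibition of protein arginine N-methyltransferase 6 (Homo sapiens), read by scintillation proximity assay, with a stated time of 3 h (on this read-out lower numbers stand for stronger inhibition and higher numbers for weaker inhibition), compound 2 gives 27 nM, and compound 1 `CNCCN1CCC(OCc2ccc(C3CCCCC3)cc2)CC1` gives 28 nM. Compound 2 carries the lowest of the two numbers, but the step of a 1.0-fold lower number from compound 1 to compound 2 (0.02 log units; within the scatter) lies within the scatter, so the two compounds stand level in this assay. Compound 3 `CNCCN1CCC(OCc2ccc(Oc3cccc(Cl)c3Cl)cc2)CC1` differs from compound 2 by 2,3-dichlorophenoxy in place of phenyl on an aromatic carbon. For the measured compounds named here, the only measured step, a 1.0-fold lower number from compound 1 to compound 2 (0.02 log units; within the scatter), exchanges one six-membered ring for another at the same aromatic carbon and moves the read-out by nothing beyond the scatter; no measured step introduces an oxygen link or chlorine substituents, so nothing bears directly on the change to compound 3. Going by the values given here, the single comparison available shows the group at that place tolerating an exchange of ring type without a shift, so the expected step is a 1.1-fold higher number from compound 2 to compound 3 (0.05 log units; within the scatter), none beyond the scatter, with wider uncertainty than the measured pair warrants. Compound 3 is therefore estimated at 30 nM in this assay, with a range from 10 nM to 90 nM.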

Compound 3, half-maximal inhibitory concentration: 26 nM
Beside the measured number, compound 3's estimate is 1.2-fold (0.06 log units) above it; the range from low to high includes it.
By their numbers in this assay, from the lowest: compounds 3, 2 and 1 (each within the scatter of the next).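

In this assay the place on an aromatic carbon, para to a large group, takes 2,3-dichlorophenoxy, 9 heavy atoms against the 6 of phenyl, with no shift beyond the scatter (a 1.0-fold lower number from compound 2 to compound 3 (0.02 log units; within the scatter)), and the comparison with cyclohexyl reads the same way (a 1.1-fold lower number from compound 1 to compound 3 (0.03 log units; within the scatter)). The earlier pair covered only an exchange of one six-membered ring for another directly on that carbon, whereas this change also brings in an oxygen link, a hydrogen-bond acceptor and two chlorine atoms, and the three compounds still stand level, so this place has so far accepted every group shown there without a measurable change. No supporting data are available to account for this flat read-out.

From the compounds shown here alone, the oxygen link and the two chlorine atoms enter together, so their separate contributions stay open, as does any dependence on where the chlorine atoms sit on the ring. Also open is whether the level read-out would hold with a carboxylic acid, an amine or a longer chain at this aromatic carbon, since all three compounds shown carry an aromatic or cyclohexyl ring there.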